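Chloro in place of methyl on the aromatic ring

A few compounds are considered here, and "the series" means these few. Any claim that something is new, unique, unknown or untested is made for them only; others in the source may bear on it.

Compound 1 `CC1=NC(C)=C(C(=O)O)C(c2ccc([N+](=O)[O-])cc2)/C1=C(\O)OC/C=C/c1ccccc1` and compound 2 `CC1=NC(C)=C(C(=O)O)C(c2cccc(C)c2)/C1=C(\O)OC/C=C/c1ccccc1` share one core and differ only in the group carried on the saturated ring carbon. In a functional assay on IMR-32 cells for inhibition of Voltage-dependent N-type calcium channel subunit alpha-1B (Homo sapiens), read by calcium flux (on this read-out higher numbers stand for weaker inhibition and lower numbers for stronger inhibition), compound 1 gives 21000 nM, and compound 2 gives 1800 nM. For the measured compounds named here, the single measured step, a 12-fold lower number from compound 1 to compound 2 (1.07 log units; beyond the scatter), is the only comparison available, and on it compound 2 stands at the lowest of the two numbers.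

Compound 3 `CC1=NC(C)=C(C(=O)O)C(c2cccc(Cl)c2)/C1=C(\O)OC/C=C/c1ccccc1` is the next member; it differs from compound 2 by chloro in place of methyl on an aromatic carbon. Going by the values given here, no measured step exchanges chloro for methyl. Among the compounds with values here, the one step known, which exchanged both the group and its position on the ring, does not read directly onto a swap of two groups of one heavy atom each at the same place, and nothing in the two numbers argues for a move in either direction. The step expected in this assay is therefore a 1.1-fold lower number from compound 2 to compound 3 (0.05 log units; within the scatter), within the scatter and without a clear direction. Compound 3 is estimated at 1600 nM, with a range from 500 nM to 5000 nM.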

Compound 3, half-maximal inhibitory concentration: 1000 nM
Estimate against measurement, compound 3: 1.6-fold (0.20 log units) above; the measured number falls inside the stated range.
By their numbers in this assay, from the lowest: compounds 3 and 2 (each within the scatter of the next); then compound 1.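

In this assay, chloro in place of methyl on an aromatic carbon, meta to a large group, gives a 1.8-fold lower number from compound 2 to compound 3 (0.26 log units; within the scatter) and so leaves the two groups unseparated at this position. The two groups are each of one heavy atom, and this read-out draws no distinction between them here. The other new step, a 21-fold lower number from compound 1 to compound 3 (1.32 log units; beyond the scatter) with 3-chlorophenyl in place of 4-nitrophenyl, shows that the large gap to compound 1 is not tied to 3-methylphenyl but recurs with a second group. No measurement here bears on what lies behind either step.

From the compounds shown here alone, both steps from compound 1 change the group and its place on the ring together, so what the place alone contributes, apart from the group, stays open. Also open, going by these compounds, is how an amine, a methoxy group or a carboxylic acid on the same aromatic carbon would read in this assay beside methyl and chloro.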